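Swapping the Amine on the Dithiocarbamate Carbon

The source may hold more compounds than are shown below. What is called first, only, known or untested is meant among the compounds shown, and "the series" means these compounds.

Measured so far in a functional assay on MGC-803 cells (Homo sapiens) for antiproliferative activity, read by CCK-8 assay, with a stated time of 72 h, tested at 2 uM; on this read-out higher numbers stand for a stronger effect at the one concentration tested and lower numbers for a weaker effect:
compound 1 `Nc1ccccc1NC(=O)c1ccc(CSC(=S)N2CCN(c3ccccc3)CC2)cc1`: 42.3%
compound 2 `Nc1ccccc1NC(=O)c1ccc(CSC(=S)N2CCc3ccccc32)cc1`: 44%
compound 3 `Nc1ccccc1NC(=O)c1ccc(CSC(=S)N2CCN(c3cccnc3)CC2)cc1`: 27.6%

Compound 2 stands at the top of the three numbers, but compound 1 sits within the scatter of it, so the two cannot be told apart; only compound 3 is clearly lower. For the measured compounds named here, the one step between measured compounds is a number 14.7 percentage points lower from compound 1 to compound 3 (beyond the scatter), brought about by pyridin-3-yl in place of phenyl on an amine nitrogen in a ring.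

Compound 4 `CC1CCCCN1C(=S)SCc1ccc(C(=O)Nc2ccccc2N)cc1` differs from compound 2 by 2-methylpiperidin-1-yl in place of 2,3-dihydro-1H-indol-1-yl on a thiocarbonyl carbon. The measured step concerns a different site and a different kind of exchange, so it bears only loosely on this one; it shows that a change to the group on the thiocarbonyl side of the molecule can move the read-out by a modest amount. With the aromatic ring of the dihydroindolyl group gone, a small loss or no change beyond the scatter is expected. Compound 4 is therefore expected to give 35% in this assay, within a range from 20% to 50%. That estimate means an expected step of a number 9 percentage points lower from compound 2 to compound 4 (within the scatter).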

Compound 4, a percentage reported as inhibition, at one concentration (the size of the read-out at that concentration, not a potency): 64.4%
Estimate against measurement, compound 4: 29.4 percentage points below; measured number above the stated range.
By their numbers in this assay, from the lowest: compound 3; then compounds 1 and 2 (each within the scatter of the next); then compound 4.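

In this assay, for the compounds shown here, the group on the thiocarbonyl carbon turns out to be able to raise the read-out as well as lower it: the one earlier step on this side of the molecule was a fall, whereas 2-methylpiperidin-1-yl in place of 2,3-dihydro-1H-indol-1-yl gives a number 20.4 percentage points higher from compound 2 to compound 4 (beyond the scatter), a step beyond the scatter. It also shows that a group with no aromatic ring can stand on this carbon without any loss in this read-out, since the entering group has one six-membered non-aromatic ring and the leaving group carried an aromatic one. Nothing available explains why this exchange raises the number.

The exchange alters the ring and adds a methyl group in one step, so the compounds shown leave open which of the two changes carries the gain, and how piperidin-1-yl without the methyl group or morpholin-4-yl would stand on this carbon. They also leave open whether the gain at this one concentration would carry over to potency, as the read-out gives the size of an effect and not a potency.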